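A few compounds are considered here, and "the series" means these few. Any claim that something is new, unique, unknown or untested is made for them only; others in the source may bear on it.

Compound 1 `Cc1ccc(S(=O)(=O)/N=C(/CCNC2=CC(=O)c3ccccc3C2=O)Nc2ccccc2[N+](=O)[O-])cc1`, compound 2 `Cc1ccc(S(=O)(=O)/N=C(/CCNC2=CC(=O)c3ccccc3C2=O)Nc2cccc(C)c2)cc1` and compound 3 `Cc1ccc(S(=O)(=O)/N=C(/CCNC2=CC(=O)c3ccccc3C2=O)NCc2ccccc2)cc1` share one core and differ only in the group carried on one amine nitrogen. In an ADME assay on HEK293 cells (Homo sapiens) for cytotoxicity, read by MTT assay, with a stated time of 48 h (a higher number here means a weaker inhibitor, a lower number a stronger inhibitor), compound 1 gives 69600 nM, compound 2 gives 56200 nM and compound 3 gives 80200 nM. The three steps between them, a 1.2-fold lower number from compound 1 to compound 2 (0.09 log units; within the scatter), a 1.2-fold higher number from compound 1 to compound 3 (0.06 log units; within the scatter) and a 1.4-fold higher number from compound 2 to compound 3 (0.15 log units; within the scatter), all fall within the scatter, so compound 3 sits alongside the other two rather than apart from them. Compound 4 `Cc1ccc(S(=O)(=O)/N=C(/CCNC2=CC(=O)c3ccccc3C2=O)NC2CCCCC2)cc1` differs from compound 3 by cyclohexyl in place of benzyl on an amine nitrogen. Within the data shown here, no measured step exchanges an aromatic ring for a non-aromatic one, and the swaps seen so far moved nothing beyond the scatter, so compound 4 is expected to show a 1.0-fold lower number from compound 3 to compound 4 (0.00 log units; within the scatter) in this assay. Compound 4 is estimated at 80000 nM, with a range from 40000 nM to 160000 nM.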

Compound 4, half-maximal inhibitory concentration: 50100 nM
Compound 4: middle estimate off by 1.6-fold (0.20 log units), on the high side; measured number inside the range.
By their numbers in this assay, from the lowest: compounds 4, 2, 1 and 3 (each within the scatter of the next).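

In this assay, among these compounds, the first exchange of an aromatic ring for a non-aromatic one on this amine nitrogen, cyclohexyl for benzyl, gives a 1.6-fold lower number from compound 3 to compound 4 (0.20 log units; within the scatter) and so stays within the scatter. Cyclohexyl also stays within the scatter against the other two groups, with a 1.1-fold lower number from compound 2 to compound 4 (0.05 log units; within the scatter) and a 1.4-fold lower number from compound 1 to compound 4 (0.14 log units; within the scatter) as its steps, so among these four compounds aromaticity of this ring makes no readable difference. No supporting data here say why these numbers stay so close. Still open, from the compounds shown here alone, is whether a straight alkyl chain on this nitrogen, or a ring carrying a carboxylic acid or an amine, would move the number beyond the scatter.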